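Swapping piperidin-4-yl on the side chain of compound 3

This account rests on a few compounds, and the source may have more. Where it says the series, first, only, none or still open, it means among the compounds named here.

In a physicochemical assay for solubility, read by nephelometry, measured as kinetic solubility, with a stated time of 30 min (a lower number here means a less soluble compound, a higher number a more soluble compound), compound 1 `c1cc([C@H]2CC[C@]3(CC2)OOC2(O3)C3CC4CC(C3)CC2C4)ccc1OCCOC1CCNCC1` gives 50 ug/mL as a true number. Compound 2 `CC(C)(O)CNCCCOc1ccc([C@H]2CC[C@]3(CC2)OOC2(O3)C3CC4CC(C3)CC2C4)cc1` reports > 100 ug/mL, which is a limit. Compound 3 `c1cc([C@H]2CC[C@]3(CC2)OOC2(O3)C3CC4CC(C3)CC2C4)ccc1OCCC1CCNCC1` also reports only a limit, > 100 ug/mL, and no number. Compound 4 `CS(=O)(=O)N1CCN(CCCOc2ccc([C@H]3CC[C@]4(CC3)OOC3(O4)C4CC5CC(C4)CC3C5)cc2)CC1` differs from compound 3 as follows: (4-(methylsulfonyl)piperazin-1-yl)methyl in place of piperidin-4-yl on a saturated chain carbon, two bonds along the chain from an oxygen on an aromatic ring, with (4-(methylsulfonyl)piperazin-1-yl)methyl in place of piperidin-4-yl. Two measured steps at this place bear on it: an at least 2.0-fold higher number from compound 1 to compound 2 (0.30 log units; that floor lies within the scatter) and an at least 2.0-fold higher number from compound 1 to compound 3 (0.30 log units; that floor lies within the scatter). Neither brings in the entering group, and both rest on limits. Within the data shown here, the one true number, compound 1 at 50 ug/mL, anchors the expectation. The expected change is an at least 2.8-fold lower number from compound 3 to compound 4 (0.45 log units; beyond the scatter), downward and uncertain in size. For compound 4 the estimated value is 35 ug/mL, with an expected range of 10 ug/mL to 100 ug/mL.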

Compound 4, solubility: < 1.6 ug/mL
Compound 4: only a limit was reported (the forecaster's own chance of this, stated with the estimate: 20%); middle value at least 21-fold (1.33 log units) away from the limit.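

In this assay compound 4 reports < 1.6 ug/mL, which is a limit. At this place on the chain, (4-(methylsulfonyl)piperazin-1-yl)methyl gives an at least 62-fold lower number from compound 3 to compound 4 (1.79 log units; beyond the scatter), alongside an at least 62-fold lower number from compound 2 to compound 4 (1.79 log units; beyond the scatter) and an at least 31-fold lower number from compound 1 to compound 4 (1.49 log units; beyond the scatter). Among these compounds, all three steps lie beyond the scatter and point downward, whereas the earlier steps at this place had floors within the scatter and pointed upward.

The compounds shown leave open whether the fall belongs to the methylsulfonyl group or to the ring that carries it, a question that a plain piperazin-1-yl at this place would address.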